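This account rests on a few compounds, and the source may have more. Where it says the series, first, only, none or still open, it means among the compounds named here.

Of the compounds shown here, two of a shared core have been measured in a functional assay on HL-60 cells (Homo sapiens) for antiproliferative activity, read by MTT assay, with a stated time of 72 h; a lower number here means a stronger inhibitor, a higher number a weaker inhibitor. Compound 1 `CN(C(=O)c1ccc(Br)cc1)c1ccc2[nH]c(-c3n[nH]c4ccccc34)cc2n1` carries a (4-bromophenyl)carbonyl on the nitrogen of its core; in this assay compound 1 gives 1080 nM. Compound 2 `CN(C(=O)c1ccccc1)c1ccc2[nH]c(-c3n[nH]c4cc(Cl)ccc34)cc2n1` differs from it in more than one place, and in this assay compound 2 gives 5620 nM. Compound 1 therefore stands at the lower of the two numbers, and the gap between the two values is beyond the usual scatter, so compound 1 is the stronger of the two.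

The next compound, compound 3 `CN(c1ccc2[nH]c(-c3n[nH]c4ccccc34)cc2n1)S(=O)(=O)c1ccc(Br)cc1`, is separated from compound 1 by a single change: (4-bromophenyl)sulfonyl in place of (4-bromophenyl)carbonyl on a nitrogen on an aromatic ring. Going by the values given here, no measured pair in this set shows a step of this kind, so the size of the step cannot be read off from anything already in hand. Given that the ring and its bromine are kept and only the link to the nitrogen is altered, compound 3 is expected to land somewhat weaker than compound 1, a step of a 2.3-fold higher number from compound 1 to compound 3 (0.36 log units; beyond the scatter), though a result within the scatter of compound 1 would not be surprising. The expected value for compound 3 in this assay is 2500 nM, with a range from 600 nM to 12000 nM.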

Compound 3, half-maximal inhibitory concentration: 6240 nM
For compound 3 the middle estimate is 2.5-fold (0.40 log units) below the measured one; low and high end bracket the measured number.
By their numbers in this assay, from the lowest: compound 1; then compounds 2 and 3 (each within the scatter of the next).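

Going by these compounds alone, on a nitrogen on an aromatic ring, this is the first comparison in the set that changes only one place, and it shows that the link to the nitrogen matters in this assay: (4-bromophenyl)sulfonyl in place of (4-bromophenyl)carbonyl gives a 5.8-fold higher number from compound 1 to compound 3 (0.76 log units; beyond the scatter). The ring and its bromine are the same in both compounds, so the loss in this pair goes with the exchange of carbonyl for sulfonyl alone, and on this core the carbonyl link is the stronger of the two. Nothing available explains the size of this step or what lies behind it.

One pair cannot say whether the same step would appear with a different group in place of the bromine, such as a methoxy or a fluorine, or on a core that carries other changes. It also leaves open how a simple methylene link would compare with carbonyl and sulfonyl, and what would follow from an ethyl group or a plain hydrogen in place of the methyl on that nitrogen.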